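The compounds below may be only part of what the source reports. "The series", "measured", "known", "first", "only" and "open" are said of these compounds alone.

Compound 1 `FC(F)(F)c1cccc(-c2nc3cnc(Nc4ccccn4)cc3[nH]2)c1`: 69%
Compound 2 `COc1cccnc1Nc1cc2[nH]c(-c3cccc(C(F)(F)F)c3)nc2cn1`: 69%
Compound 3 `FC(F)(F)c1cccc(-c2nc3cnc(Nc4ccncn4)cc3[nH]2)c1`: 90%

These three compounds share one core and were all tested in an ADME assay on microsomes from liver (Homo sapiens) for metabolic stability, read by LC-MS, with a stated time of 30 min, tested at 0.1 uM; a lower number here means that less of the compound is left, a higher number that more of the compound is left. Compound 1 stands level with compound 2 at the digits shown, and together they sit at the lower end of the three numbers, while compound 3 lies higher, by a number 21 percentage points higher from compound 1 to compound 3 (beyond the scatter). The same gap is seen in a number 21 percentage points higher from compound 2 to compound 3 (beyond the scatter).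

The new compound 4 `CN1CCN(c2ccc(Nc3cc4[nH]c(-c5cccc(C(F)(F)F)c5)nc4cn3)nc2)CC1` differs from compound 1 in one place: 4-methylpiperazin-1-yl in place of hydrogen on an aromatic carbon.

Within the data shown here, the measured step that bears most directly on this change is the one from compound 1 to compound 2, where a group was also put onto an aromatic carbon of the same ring and the result was no change at the digits printed from compound 1 to compound 2 (within the scatter). The two steps that led to a higher number both exchanged the ring itself for a pyrimidin-4-yl ring, which is not what happens here, so they offer little guidance. On this basis the change into compound 4 is expected to bring no step beyond the scatter in this assay, which corresponds to an expected step of a number 4 percentage points lower from compound 1 to compound 4 (within the scatter).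

Compound 4 is therefore estimated to give 65% in this assay, with a range from 45% to 85%.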

Compound 4, percent of the compound remaining: 68%
For compound 4 the middle estimate is 3 percentage points below the measured one; the measured number falls inside the stated range.
By their numbers in this assay, from the lowest: compounds 4, 1 and 2 (each within the scatter of the next); then compound 3.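

In this assay, the step from a bare ring carbon to 4-methylpiperazin-1-yl is a number 1 percentage points lower from compound 1 to compound 4 (within the scatter). Among these compounds, until now, the only group added to the pyridin-2-yl ring was a single methoxy, so the earlier compounds could not show what a far larger addition would do. This result shows that a whole six-membered non-aromatic ring with 2 hetero atoms, placed two atoms from the ring nitrogen and para to a large group, gives no step beyond the scatter, so this carbon can carry a bulky group without a measurable shift in the percent of compound remaining.

The compounds shown leave open whether other groups on this carbon, such as a morpholine ring, a carboxylic acid or a longer chain ending in an amine, would behave the same way. They also leave open whether 4-methylpiperazin-1-yl could be carried over to the pyrimidin-4-yl ring of compound 3, which gives 90%, without moving that number.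

Nothing measured here explains why this large addition leaves the reading within the scatter.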